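A Ring Swap on a Core Without Measured Activity

This account rests on a few compounds, and the source may have more. Where it says the series, first, only, none or still open, it means among the compounds named here.

Of the compounds shown here, three have so far been tested in a functional assay on KYSE-410 cells (Homo sapiens) for antiproliferative activity, read by MTT assay, with a stated time of 72 h; a higher number here means a weaker inhibitor, a lower number a stronger inhibitor. Compound 1 `COc1ccccc1NC(=O)c1ccnc2cc(Br)ccc12` gives > 20000 nM, which is a limit of the assay rather than a number. Compound 2 `COc1ccc(NC(=O)c2cc(=O)[nH]c3cc(Br)ccc23)cc1` likewise reaches only the limit of > 20000 nM. Compound 3 `CC(=O)c1ccc(-c2ccc3c(C(=O)Nc4cccc(F)c4)cc(=O)[nH]c3c2)cc1` also sits at the limit of > 20000 nM. Compound 3 therefore stands nowhere distinct among the numbers shown: the limit of > 20000 nM in this assay, at which 3 of the 3 values shown sit. None of the three values is a real number. For the measured compounds named here, no step between any two measured compounds can be drawn, and there is no measured change to lean on.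

Compound 4 `O=C(Nc1cccc(F)c1)c1cc(=O)[nH]c2cc(C3=CCOCC3)ccc12` differs from compound 3 in one place. a group of 6 heavy atoms (5 carbon, 1 oxygen; one six-membered non-aromatic ring with 1 hetero atom) in place of a group of 9 heavy atoms (8 carbon, 1 oxygen; one six-membered aromatic ring of carbon only), on an aromatic carbon Nothing measured yet shows what such a change does to this assay, so the direction and size of the step can only be guessed from the fact that every neighbour of compound 4 is at the limit. The expected step, a step that the limit leaves unreadable from compound 3 to compound 4, is none beyond the scatter. Compound 4 is thus estimated to come in near 25000 nM, within a range from 8000 nM to 60000 nM, and most likely this assay will once more report only a limit for it.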

Compound 4, half-maximal inhibitory concentration: 12100 nM
Estimate against measurement, compound 4: 2.1-fold (0.32 log units) above, and the stated range covers the measured number.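

In this assay, for the compounds shown here, compound 4 gives the first real number of the series, which shows that the shared core can yield a measurable reading with a suitable group at this aromatic carbon. Putting a six-membered non-aromatic ring with 1 hetero atom in place of the 4-acetylphenyl group brings an at least 1.6-fold lower number from compound 3 to compound 4 (0.21 log units; that floor lies within the scatter), so a six-membered aromatic ring of carbon only is not needed here for such a reading, although the step as printed gives only a floor and does not establish a change beyond the scatter. The true size of the step remains unknown, and compound 4 stands alone as the only compound with a number: the limit of > 20000 nM in this assay, at which 3 of the 4 values shown sit.

The compounds shown leave open whether the oxygen in the new ring matters, which a ring of carbon only, such as cyclohexenyl, or a ring carrying nitrogen, such as a piperidine, could help to settle. They also leave open whether the double bond in that ring plays any part, and whether a fully saturated tetrahydropyranyl ring or a much smaller group, such as a methyl, would move the number further in either direction.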